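The compounds below may be only part of what the source reports. "The series", "measured", "known", "first", "only" and "open" are said of these compounds alone.

Measured so far:
compound 1, `COc1nc(=O)ccn1[C@@H]1O[C@H](COP(=O)(O)O)[C@@H](O)[C@H]1O` — 9900 nM
compound 2, `CSc1nc(=O)ccn1[C@@H]1O[C@H](COP(=O)(O)OP(=O)(O)O)[C@@H](O)[C@H]1O` — 523 nM

Among the measured compounds shown here, compound 1 has the highest of the two numbers in an in vitro functional assay on 1321-N1 cells for agonist activity at P2Y purinoceptor 2 (Homo sapiens), read by scintillation proximity assay and inositol phosphate accumulation; a higher number here means that more compound is needed for the effect, a lower number that less compound is needed; compound 2 sits at a lower number, a gap that lies beyond the usual scatter, but the two structures differ in more than one place, so no single step is drawn between them.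

The piece follows compound 1 to compound 3, `CCCSc1nc(=O)ccn1[C@@H]1O[C@H](COP(=O)(O)O)[C@@H](O)[C@H]1O`. The change is propylsulfanyl in place of methoxy on an aromatic carbon. For the measured compounds named here, no measured pair mirrors this change, so what to expect rests on the two values alone. Compound 2, with a sulfur-linked group on the same part of the shared core, gives 523 nM, which hints, weakly, that a sulfur group is not harmful. For compound 3 the step of a 2.5-fold lower number from compound 1 to compound 3 (0.39 log units; beyond the scatter) is expected to be modest, toward a lower number. Compound 3 is thus estimated at 4000 nM, within a range of 1000 nM to 20000 nM.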

Compound 3, half-maximal effective concentration: 4800 nM
Compound 3: the middle estimate sits 1.2-fold (0.08 log units) below what was measured; the measured number falls inside the stated range.
By their numbers in this assay, from the lowest: compound 2; then compound 3; then compound 1.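

In this assay, putting propylsulfanyl in place of methoxy, on the aromatic carbon between two ring nitrogen atoms, gives a 2.1-fold lower number from compound 1 to compound 3 (0.31 log units; beyond the scatter). Among the compounds shown here, this is the first comparison at this position in which only one group changes, and it shows that a larger, sulfur-linked group can replace methoxy there without raising the number. No measured evidence here accounts for the modest size of this step.

The sulfur atom and the longer chain enter together, so the compounds shown leave open which of the two matters, and a propoxy group at this position would separate them. They also leave open how the number responds to an amine or to a longer chain such as hexylsulfanyl on the same carbon.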